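The source may report more compounds than this note shows. Statements on the series, on what has been measured and on what is new or still open speak of the compounds shown alone.

Working notes on the series. All members share one core and differ only in the group on an aromatic carbon of the five-membered aromatic ring with 3 nitrogen. Compound 1 `CCCCCCc1cn(C(c2ccccc2)c2cc3cc(Br)ccc3nc2OC)nn1` carries hexyl there, and in an ADME assay on HEK293 cells (Homo sapiens) for cytotoxicity, read by sulforhodamine B assay, with a stated time of 48 h, tested at 10 uM (on this read-out lower numbers stand for less inhibition and higher numbers for more inhibition at the one concentration tested (going by the name of the read-out)), compound 1 gives -3.17%. Compound 2 `COc1nc2ccc(Br)cc2cc1C(c1ccccc1)n1cc(-c2ccccc2)nn1` carries phenyl, and in this assay compound 2 gives 8.25%. Compound 3 `CCCCCCCCc1cn(C(c2ccccc2)c2cc3cc(Br)ccc3nc2OC)nn1` carries octyl, and in this assay compound 3 gives 14.6%, the highest of the three numbers; its gap to compound 2 lies within the scatter, its gap to compound 1 beyond it. The measured steps at this carbon are a number 11.4 percentage points higher from compound 1 to compound 2 (beyond the scatter), a number 17.8 percentage points higher from compound 1 to compound 3 (beyond the scatter) and a number 6.4 percentage points higher from compound 2 to compound 3 (within the scatter).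

Among the compounds with values here, compound 4 `CCOC(=O)c1cn(C(c2ccccc2)c2cc3cc(Br)ccc3nc2OC)nn1` is the next member. ethoxycarbonyl in place of octyl on an aromatic carbon None of the measured steps places an ethoxycarbonyl on that carbon; they only show the span covered so far by hexyl, phenyl and octyl, and all of them are modest. Compound 4 leaves that set of groups, so no step beyond the scatter is firmly expected, though a number toward the middle of the measured range seems more likely than one above compound 3. For compound 4 in this assay the estimate is 4% with a range from -8% to 16%, which means an expected step of a number 10.6 percentage points lower from compound 3 to compound 4 (beyond the scatter).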

Compound 4, a percentage reported as inhibition, at one concentration (the size of the read-out at that concentration, not a potency): 2%
Beside the measured number, compound 4's estimate is 2 percentage points above it; the range from low to high includes it.
By their numbers in this assay, from the lowest: compounds 1, 4, 2 and 3 (each within the scatter of the next, the first and the last beyond it).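

Replacing octyl with ethoxycarbonyl, the first group at this aromatic carbon shown here with a double bond outside aromatic rings and with hydrogen-bond acceptors in its count, gives a number 12.6 percentage points lower from compound 3 to compound 4 (beyond the scatter) in this assay, so a group with fewer heavy atoms and a different make-up can separate from the octyl end of the series. The same group set against the other two gives a number 6.3 percentage points lower from compound 2 to compound 4 (within the scatter) and a number 5.2 percentage points higher from compound 1 to compound 4 (within the scatter), so among the groups at this carbon ethoxycarbonyl is separated from octyl alone and not from phenyl or hexyl. Nothing on hand accounts for the step from octyl to ethoxycarbonyl or says which feature of either group matters.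

From the compounds shown here alone, whether the free carboxylic acid or a primary amide at this carbon would stay with ethoxycarbonyl remains open, and so does whether the ester's oxygen atoms or the removal of chain length matters for the step. A chain longer than octyl, or an aminoalkyl chain of octyl length, would help show whether the gap seen in a number 17.8 percentage points higher from compound 1 to compound 3 (beyond the scatter) goes on growing with chain length or depends on the chain's atoms.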